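The source may hold more compounds than are shown below. What is called first, only, known or untested is meant among the compounds shown, and "the series" means these compounds.

For the measured compounds named here, only two compounds with the shared core have been tested so far. In a functional assay on Mahlavu cells (Homo sapiens) for inhibition, read by sulforhodamine B assay, with a stated time of 72 h (on this read-out lower numbers stand for stronger inhibition and higher numbers for weaker inhibition), compound 1 `Cc1ccc([S@+]([O-])C2=C(Cl)C(=O)C=CC2=O)cc1` is reported as "not active" (no number reported), with no number attached. Going by the values given here, compound 2 `Cc1ccc([S@+]([O-])C2=CC(=O)C=CC2=O)cc1` gives 31300 nM, so it holds the only number available and there is nothing to rank it against. The next compound, compound 3 `COC1=CC(=O)C([S@@+]([O-])c2ccc(C)cc2)=CC1=O`, differs from compound 2 by one change: methoxy in place of hydrogen on a double-bonded ring carbon. Among the compounds with values here, no measured pair shows what such a change does in this assay, so there is little to go on and no firm direction can be given. The expected result is no shift beyond the usual scatter, and the estimated step is a 1.3-fold lower number from compound 2 to compound 3 (0.10 log units; within the scatter). Compound 3 is estimated at 25000 nM, with an expected range of 8000 nM to 70000 nM.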

Compound 3, half-maximal inhibitory concentration: 11300 nM
For compound 3 the middle estimate is 2.2-fold (0.34 log units) above the measured one; measured number inside the range.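

In this assay, the pair of compound 2 and compound 3 gives the first measured direction for this position: methoxy in place of hydrogen on a double-bonded ring carbon comes with a 2.8-fold lower number from compound 2 to compound 3 (0.44 log units; beyond the scatter). The step is modest, but it shows that this ring carbon can carry methoxy without inhibition being lost, and that the number in fact falls. Nothing available here explains why the number moves.

Going by these compounds, whether this result is particular to methoxy remains open, and a longer chain such as ethoxy, an amine or a carboxylic acid on the same carbon would help to show that. A single pair also cannot tell whether methoxy would give a similar step on another compound with the shared core.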